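Phenyl for cyclohexyl on two related cores

A few compounds are considered here, and "the series" means these few. Any claim that something is new, unique, unknown or untested is made for them only; others in the source may bear on it.

Compound 1 `Cc1ccc(S(=O)(=O)N2CC[C@@H](Cl)C[C@@H]2C2CCCCC2)cc1` and compound 3 `Cc1ccc(S(=O)(=O)N2CCC(Cl)=CC2C2CCCCC2)cc1` both carry a cyclohexyl group; the difference between their two cores is not broken down here. In a functional assay on SW1573 cells (Homo sapiens) for antiproliferative activity, read by sulforhodamine B assay, with a stated time of 48 h (on this read-out lower numbers stand for stronger inhibition of growth and higher numbers for weaker inhibition of growth), compound 1 gives 53000 nM. In this assay compound 3 gives 62000 nM, a value within the scatter of that of compound 1. Compound 2 `Cc1ccc(S(=O)(=O)N2CC[C@@H](Cl)C[C@@H]2c2ccccc2)cc1` differs from compound 1 by phenyl in place of cyclohexyl on a saturated ring carbon. For compound 2 this assay reports only a limit, > 100000 nM, so the step of an at least 1.8-fold higher number from compound 1 to compound 2 (0.27 log units; that floor lies within the scatter) is a floor and not a measured size. That floor is the limit of > 100000 nM in this assay, at which 1 of the 3 values shown sits. Compound 4 `Cc1ccc(S(=O)(=O)N2CCC(Cl)=CC2c2ccccc2)cc1` has not yet been measured; it differs from compound 3 by phenyl in place of cyclohexyl on a saturated ring carbon, the same change as that made on the other core, at the same place. The step expected here, a 1.9-fold higher number from compound 3 to compound 4 (0.29 log units; within the scatter), is set no smaller than the measured one because an at least 1.8-fold higher number from compound 1 to compound 2 (0.27 log units; that floor lies within the scatter) already ran into the limit of > 100000 nM in this assay, at which 1 of the 3 values shown sits, from a starting point like that of compound 3. Compound 4 is therefore estimated at 120000 nM, within a range from 60000 nM to 300000 nM, with a real chance that only a limit is reported.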

Compound 4, concentration for 50% growth inhibition: 16000 nM
The estimate for compound 4 lay 7.5-fold (0.88 log units) above the measured number; the measured number lies below the stated range.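

In this assay, phenyl in place of cyclohexyl on a saturated ring carbon gives a 3.9-fold lower number from compound 3 to compound 4 (0.59 log units; beyond the scatter), so on the core of compound 3 the change goes with stronger inhibition of growth. The change does not carry from the core of compound 1 to the core of compound 3 as a single step of one size: the same change on two cores in this assay, an at least 1.8-fold higher number (0.27 log units; that floor lies within the scatter) from compound 1 to compound 2 and a 3.9-fold lower number (0.59 log units; beyond the scatter) from compound 3 to compound 4, at least 7.3-fold (0.86 log units) apart, beyond the scatter of two such steps. The true size of the step on the core of compound 1 is not shown and no rule follows beyond these two pairs, since compound 2 is reported only as a limit: the limit of > 100000 nM in this assay, at which 1 of the 4 values shown sits.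

From the compounds shown here alone, whether a pyridine ring or a tert-butyl group on the same saturated ring carbon would follow phenyl or cyclohexyl on each core remains open. Also open, going by these compounds, is whether the difference between the two steps would persist with a group other than chloro on the ring, such as a hydroxyl or a methoxy group.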